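The source may hold more compounds than are shown below. What is called first, only, known or untested is meant among the compounds shown, and "the series" means these compounds.

Compound 1 `Cc1nc2n(c(=O)c1C(N)=O)C(C)CCC2=NNc1ccccc1`: > 100 umol/kg
Compound 2 `CCc1nc2n(c(=O)c1C(N)=O)C(C)CCC2=NNc1ccccc1`: > 100 umol/kg

In a functional assay on the whole organism with Rattus norvegicus as the target (a lower number here means that less compound is needed, a higher number that more compound is needed for the effect), compound 1 gives only a limit of the assay, > 100 umol/kg. Compound 2 likewise gives only a limit of the assay, > 100 umol/kg. For the measured compounds named here, the one step between measured compounds, a step that the two limits leave unreadable from compound 1 to compound 2, therefore cannot be read in size or direction, since the limit of > 100 umol/kg in this assay, at which 2 of the 2 values shown sit, is where both values sit. Compound 2 thus stands at the limit itself, with no number attached.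

Compound 3 `CCc1nc2n(c(=O)c1C(=O)O)C(C)CCC2=NNc1ccccc1` differs from compound 2 in one place: hydroxy in place of amino on a carbonyl carbon. Going by the values given here, no measured step bears on this change, and the single step that exists is unreadable, so the data give no size or direction to expect beyond the scatter. Resting only on compound 2, which shows > 100 umol/kg, the expected step that the limit leaves unreadable from compound 2 to compound 3 is none beyond the scatter, with the most likely outcome that compound 3 also returns only a limit. For compound 3 the estimate is 150 umol/kg in this assay, with a range from 50 umol/kg to 500 umol/kg, and the measured value would decide.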

Compound 3, dose for 50% inhibition: > 320 umol/kg
Compound 3 ended at the assay's limit; the forecaster's own chance of this, stated with the estimate: 80%; middle value at least 2.1-fold (0.32 log units) away from the limit.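

In this assay compound 3 gives only a limit of the assay, > 320 umol/kg. With compound 2 also at a limit, the change from carbamoyl to carboxy yields no readable step between compound 2 and compound 3. The compounds shown leave open how much of compound 1, compound 2 or compound 3 would be needed for the effect in this assay.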